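The source may hold more compounds than are shown below. What is called first, only, known or untested is meant among the compounds shown, and "the series" means these compounds.

The measured compounds:
compound 1, `COC(=O)c1ccc2c(c1)oc(=O)n2CCOc1ccnc2cc(OC)ccc12`, > 500 nM
compound 2, `COC(=O)c1ccc2oc(=O)n(CCOc3ccnc4cc(OC)ccc34)c2c1`, > 500 nM
compound 3, `COc1ccc2c(OCCn3c(=O)oc4cc(-c5cnn(C)c5)ccc43)ccnc2c1`, 100 nM

In a functional assay on EBC-1 cells (Homo sapiens) for inhibition, read by sulforhodamine B assay, with a stated time of 72 h (on this read-out lower numbers stand for stronger inhibition and higher numbers for weaker inhibition), compound 1 reaches only a limit, > 500 nM. Compound 2 likewise gives only a limit, > 500 nM. Compound 2 has the same atoms as compound 1, joined differently, and the difference between the two cores is not broken down here. Compound 3 gives 100 nM in this assay. The change from compound 1 to compound 3 is 1-methyl-1H-pyrazol-4-yl in place of methoxycarbonyl on an aromatic carbon, and it brought an at least 5.0-fold lower number from compound 1 to compound 3 (0.69 log units; beyond the scatter). Two of the three values sit at the limit of > 500 nM in this assay, at which 2 of the 3 values shown sit. Compound 4, `COc1ccc2c(OCCn3c(=O)oc4ccc(-c5cnn(C)c5)cc43)ccnc2c1`, is not yet measured; it carries the same change on the core of compound 2, (1-methyl-1H-pyrazol-4-yl in place of methoxycarbonyl on an aromatic carbon). Compound 4 is expected to show an at least 3.3-fold lower number from compound 2 to compound 4 (0.52 log units; beyond the scatter) in this assay, resting on an at least 5.0-fold lower number from compound 1 to compound 3 (0.69 log units; beyond the scatter). For compound 4 the estimate in this assay is 150 nM, between 40 nM and 600 nM.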

Compound 4, half-maximal inhibitory concentration: > 500 nM
Compound 4: only a limit was reported; the forecaster's own chance of this, stated with the estimate: 25%; at least 3.3-fold (0.52 log units) between middle value and limit.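

Going by these compounds alone, compound 4 gives only a limit in this assay, > 500 nM, and compound 2 also gives only a limit, so no step between them can be read. The compounds shown leave open whether 1-methyl-1H-pyrazol-4-yl in place of methoxycarbonyl changes inhibition on the core of compound 2.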